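Swapping ethyl for tert-butyl on the amide-type nitrogen

The compounds below may be only part of what the source reports. "The series", "measured", "known", "first", "only" and "open" are said of these compounds alone.

Compound 2 `CCNC(=O)CC1CCc2cc(OC)c(OC)cc21` carries an ethyl group on an amide-type nitrogen. Going by the values given here, in a functional assay on the whole organism (strain Wistar) for inhibition, with Rattus norvegicus as the target, read by paw edema, with stated times of 60 min and 4 h, at a dose of 100 mg/kg by the oral route (a lower number here means less inhibition, a higher number more inhibition at the dose given (going by the name of the read-out)), compound 2 gives 26.6%, the smaller of the two numbers recorded, yet its only neighbour, compound 1 `COc1cc2c(cc1OC)C(CC(N)=O)CC2`, which has hydrogen in that place, gives 31.3%, and the step of a number 4.7 percentage points lower from compound 1 to compound 2 (within the scatter) lies within the scatter, so the two cannot be told apart. Compound 3 `COc1cc2c(cc1OC)C(CC(=O)NC(C)(C)C)CC2` takes the same place one size larger: tert-butyl in place of ethyl on an amide-type nitrogen. Among the compounds with values here, the single measured step that bears on this change, from hydrogen to ethyl, stayed within the scatter; enlarging the group again, from ethyl to tert-butyl, has no measured precedent here. The step of a number 1.6 percentage points lower from compound 2 to compound 3 (within the scatter) is therefore expected to remain within the scatter, with no clear direction. Compound 3 is estimated at 25%, within a range from 10% to 40%.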

Compound 3, a percentage reported as inhibition, in the whole organism at one dose (the size of the read-out at that dose, not a potency): 32.8%
For compound 3 the middle estimate is 7.8 percentage points below the measured one, and the stated range covers the measured number.
By their numbers in this assay, from the lowest: compounds 2, 1 and 3 (each within the scatter of the next).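

In this assay, the step for this change is a number 6.2 percentage points higher from compound 2 to compound 3 (within the scatter), and replacing the amide hydrogen directly with tert-butyl gives a number 1.5 percentage points higher from compound 1 to compound 3 (within the scatter). Both steps stay within the scatter, so hydrogen, ethyl and tert-butyl on the amide-type nitrogen cannot be told apart at this dose. Across these three compounds, even the group with 4 carbon atoms shows no measurable link between the size of the group and the inhibition of paw edema. No outside measurement is available to bear on this result.

The compounds shown leave open whether a group of another kind on this nitrogen, such as a phenyl ring or a longer chain ending in an amine, would give a step beyond the scatter. They also leave open what a carboxylic acid in place of the amide would do.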